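The source may report more compounds than this note shows. Statements on the series, on what has been measured and on what is new or still open speak of the compounds shown alone.

Compound 1 `COc1ccc(Br)cc1C(=O)Nc1ccc(Sc2nc3ccccc3s2)cc1` was tested in an assay for inhibition of HSP60/HSP10 (Homo sapiens), with a stated time of 60 min; a higher number here means a weaker inhibitor, a lower number a stronger inhibitor. In this assay compound 1 reaches only the limit > 100000 nM, which is not a number. Compound 2 `O=C(Nc1ccc(Sc2nc3ccccc3s2)cc1)c1ccccc1` carries a phenyl in place of 5-bromo-2-methoxyphenyl on a carbonyl carbon. In this assay compound 2 also stops at the limit > 100000 nM, so its standing is known only as a limit. The step that the two limits leave unreadable from compound 1 to compound 2 cannot be read; the one firm point is the limit of > 100000 nM in this assay, at which 2 of the 2 values shown sit. Compound 3 `COc1c(Br)cccc1C(=O)Nc1ccc(Sc2nc3ccccc3s2)cc1` is the next compound, and the change leading to it is a group of 9 heavy atoms (7 carbon, 1 oxygen, 1 bromine; one six-membered aromatic ring of carbon only) in place of a group of 6 heavy atoms (6 carbon; one six-membered aromatic ring of carbon only), on a carbonyl carbon, the entering group being a bromo-methoxyphenyl. Among the compounds with values here, the single measured step is unreadable; no readable step bears on this change. Compound 3 is expected to sit at the limit as well. The expected step that the limit leaves unreadable from compound 2 to compound 3 is accordingly not beyond the scatter. The estimate for compound 3 is 150000 nM, ranging from 50000 nM to 500000 nM, most likely reported as a limit rather than a number.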

Compound 3, half-maximal inhibitory concentration: > 100000 nM
Compound 3: no number, only a limit; the forecaster's own chance of this, stated with the estimate: 85%; the middle value does not contradict the limit.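

Compound 3, like compound 1 and compound 2, gives only a limit and no number in this assay, so no step among these three compounds can be read: the limit of > 100000 nM in this assay, at which 3 of the 3 values shown sit. The compounds shown leave open which group on the carbonyl carbon, if any, would give a readable number.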